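This account rests on a few compounds, and the source may have more. Where it says the series, first, only, none or still open, it means among the compounds named here.

The measured compounds:
Compound 1, `CNC(=O)c1ccc(Sc2ccc(NC(=S)Nc3ccc(OC(F)(F)F)cc3)cc2)nc1`: > 100000 nM
Compound 2, `CNC(=O)c1ccc(Sc2cccc(NC(=S)Nc3ccc(F)c(F)c3)c2)nc1`: 35100 nM

Both were tested in a functional assay on HCT-116 cells (Homo sapiens) for cytotoxicity, read by MTT assay, with a stated time of 48 h; a higher number here means a weaker inhibitor, a lower number a stronger inhibitor. For compound 1 the value > 100000 nM is a limit of the assay rather than a number, as marked by the limit of > 100000 nM in this assay, at which 1 of the 2 values shown sits. Compound 2 gives 35100 nM in this assay, and this is the only actual number shown among the two compounds. For the measured compounds named here, with one number and one limit, no step between measured compounds can be drawn, so there is nothing yet on how a change at this part of the molecule moves the read-out.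

Compound 3, `CNC(=O)c1ccc(Sc2cccc(NC(=S)Nc3cccc(C(F)(F)F)c3)c2)nc1`, has not yet been tested. It differs from compound 2 in one place: 3-(trifluoromethyl)phenyl in place of 3,4-difluorophenyl on an amide-type nitrogen. Without a measured step to lean on, the expectation rests on compound 2 alone. The step from compound 2 to compound 3 in this assay is expected to be a 1.2-fold lower number from compound 2 to compound 3 (0.07 log units; within the scatter), which is no more than the usual scatter in either direction. Compound 3 is therefore estimated to give 30000 nM in this assay, within an expected range from 8000 nM to 100000 nM.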

Compound 3, half-maximal inhibitory concentration: 16200 nM
Beside the measured number, compound 3's estimate is 1.9-fold (0.27 log units) above it; the measured number falls inside the stated range.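

In this assay, for the compounds shown here, this pair gives the first step that can be read: placing 3-(trifluoromethyl)phenyl instead of 3,4-difluorophenyl on the amide-type nitrogen gives a 2.2-fold lower number from compound 2 to compound 3 (0.34 log units; beyond the scatter). The group on this nitrogen can therefore move the read-out beyond the usual scatter, though only modestly, and in this single pair the change favours 3-(trifluoromethyl)phenyl. No step to compound 1 can be read, as it differs from the other compounds in more than one place and its value is a limit rather than a number: the limit of > 100000 nM in this assay, at which 1 of the 3 values shown sits.

The compounds shown leave open whether the stronger result comes from the trifluoromethyl group itself or simply from losing the fluorine atoms of 3,4-difluorophenyl, a question that a plain phenyl ring or a ring carrying a single chlorine atom at this place could help to answer. They also leave open how the read-out would respond to quite different groups on this nitrogen, such as a cyclohexyl ring or a phenyl ring bearing a carboxylic acid or an amine.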